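The compounds below may be only part of what the source reports. "The series", "measured", "known", "first", "only" and "open" are said of these compounds alone.

Compound 1 `COc1cc(C#N)ccc1OCc1nnc(-c2ccc(C)cc2)o1` and compound 2 `N#Cc1ccc(OCc2nnc(-c3ccccc3)o2)cc1F` were both tested in an ADME assay on MCF-10A cells (Homo sapiens) for cytotoxicity, read by MTT assay, with a stated time of 48 h; a lower number here means a stronger inhibitor, a higher number a weaker inhibitor. Compound 1 gave only a limit, > 100000 nM, not a number. Compound 2 likewise gave only a limit, > 100000 nM. Both values sit on (the limit of > 100000 nM in this assay, at which 2 of the 2 values shown sit), so compound 2 stands at the edge of what this assay can report, with nothing measured beyond it. Compound 3 `N#Cc1ccc(OCc2nnc(-c3ccc(F)cc3)o2)cc1F` has not yet been measured. It differs from compound 2 by fluoro in place of hydrogen on an aromatic carbon. Among the compounds with values here, with no measured step to lean on, the step in this assay is expected to be none beyond the scatter, a number no higher from compound 2 to compound 3 (the limit leaves the size open). Compound 3 is therefore expected to give about 100000 nM, within a range from 30000 nM to 300000 nM, and most likely once more only a limit.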

Compound 3, half-maximal inhibitory concentration: 84200 nM
Beside the measured number, compound 3's estimate is 1.2-fold (0.07 log units) above it, within the range that was stated.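

Within the data shown here, compound 3 is the first compound here to give a number rather than a limit: in this assay compound 3 gives 84200 nM. Compound 2 has only a limit, > 100000 nM. Going from phenyl to 4-fluorophenyl therefore gives an at least 1.1-fold lower number from compound 2 to compound 3 (0.07 log units; that floor lies within the scatter), so the true size of the step stays unknown, and this floor alone does not show that fluoro at this place has an effect beyond the scatter.

Going by these compounds, what an amine, a carboxylic acid or a chloro group at this same place would give remains open.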